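Trichlorophenyl Ether Variant of a Dihydrofolate Reductase Inhibitor

A few compounds are considered here, and "the series" means these few. Any claim that something is new, unique, unknown or untested is made for them only; others in the source may bear on it.

Compound 1, `NC1=NC2(CCOCC2)N(OCCCOc2ccccc2)C(N)=N1`, gives 86.1 nM in an assay on isolated protein for inhibition of Dihydrofolate reductase (Homo sapiens), read by spectrophotometry, using NADPH, with stated times of 5 s and 6 min; on this read-out lower numbers stand for stronger inhibition and higher numbers for weaker inhibition.
Compound 2, `COc1ccc(OCCCON2C(N)=NC(N)=NC23CCOCC3)cc1`, gives 11.1 nM in this assay.
Compound 3, `NC1=NC2(CCOCC2)N(OCCCOc2ccc(Cl)cc2)C(N)=N1`, gives 33.6 nM in this assay.

Compound 2 holds the lowest number of the three, with compound 3 nearest and compound 1 furthest. Compound 4, `NC1=NC2(CCOCC2)N(OCCCOc2cc(Cl)c(Cl)cc2Cl)C(N)=N1`, has not been measured. It differs from compound 2 by 2,4,5-trichlorophenyl in place of 4-methoxyphenyl on an oxygen on a saturated carbon.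

Within the data shown here, two measured steps bear on this change. Replacing methoxy by chloro on the aromatic ring gave a 3.0-fold higher number from compound 2 to compound 3 (0.48 log units; beyond the scatter), while adding a single chloro to the unsubstituted ring gave a 2.6-fold lower number from compound 1 to compound 3 (0.41 log units; beyond the scatter). Among the measured compounds shown here, no measured pair shows what two further chlorines on that ring do. For the measured compounds named here, the closest precedent therefore points to a modest rise in the number, with added uncertainty from the extra chlorines. Compound 4 is expected to give 30 nM in this assay, within 8 nM to 110 nM. This estimate corresponds to an expected 2.7-fold higher number from compound 2 to compound 4 (0.43 log units; beyond the scatter).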

Compound 4, half-maximal inhibitory concentration: 36 nM
Compound 4: middle estimate off by 1.2-fold (0.08 log units), on the low side, within the range that was stated.
By their numbers in this assay, from the lowest: compound 2; then compounds 3 and 4 (each within the scatter of the next); then compound 1.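

In this assay, among these compounds, the two further chlorines that set 2,4,5-trichlorophenyl apart from 4-chlorophenyl give no step that stands out from the scatter: a 1.1-fold higher number from compound 3 to compound 4 (0.03 log units; within the scatter). The trichlorinated ring still compares well with plain phenyl, with a 2.4-fold lower number from compound 1 to compound 4 (0.38 log units; beyond the scatter), but it does not match 4-methoxyphenyl, with a 3.2-fold higher number from compound 2 to compound 4 (0.51 log units; beyond the scatter), so the ring with three chlorines adds nothing measurable here to what one chloro already gave. Nothing measured on these compounds accounts for this flat response to the further chlorines.

The compounds shown do not separate the contributions of the individual chlorines of 2,4,5-trichlorophenyl. As far as these compounds go, it also remains open how an ethoxy group, an amine or a carboxylic acid would compare with the methoxy of compound 2 on the ring, and what a longer chain carrying that ring would do.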